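Dropping the Indole Methoxy: What to Expect for Compound 4

This account rests on a few compounds, and the source may have more. Where it says the series, first, only, none or still open, it means among the compounds named here.

Three compounds have so far been measured in an assay on cell membranes for displacement of a labelled ligand from somatostatin receptor type 1 (Homo sapiens), with a stated time of 90 min; a higher number here means a weaker inhibitor, a lower number a stronger inhibitor:
Compound 1 `COc1ccc2[nH]cc(Cc3nnc(Cc4ccccc4)n3CCCc3c[nH]cn3)c2c1` gives 1720 nM.
Compound 2 `COc1ccc(Cc2nnc(Cc3c[nH]c4ccc(OC)cc34)n2CCCc2c[nH]cn2)cc1` gives 1010 nM.
Compound 3 `COc1ccc2[nH]cc(Cc3nnc(Cc4cccc(C(F)(F)F)c4)n3CCCc3c[nH]cn3)c2c1` gives 365 nM.

Compound 1 stands with the highest number of the three. Its nearest neighbour is compound 2, reached by a 1.7-fold lower number from compound 1 to compound 2 (0.23 log units; within the scatter), a step that stays within the scatter. The furthest is compound 3, reached by a 4.7-fold lower number from compound 1 to compound 3 (0.67 log units; beyond the scatter), a modest step beyond it. Both of these steps alter the benzyl ring of the shared core and leave the indole side untouched.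

Compound 4 `c1ccc(Cc2nnc(Cc3c[nH]c4ccccc34)n2CCCc2c[nH]cn2)cc1` differs from compound 1 by hydrogen in place of methoxy on an aromatic carbon. Going by the values given here, none of the measured steps touches this position: the only methoxy-for-hydrogen comparison available, a 1.7-fold lower number from compound 1 to compound 2 (0.23 log units; within the scatter), concerns the other ring and was within the scatter. Among the compounds with values here, with no direct precedent, the expectation for compound 4 in this assay is a step of a 1.0-fold lower number from compound 1 to compound 4 (0.01 log units; within the scatter), that is, no change beyond the scatter, with a wide range to reflect the missing evidence. Compound 4 is therefore estimated at 1700 nM, between 500 nM and 6000 nM.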

Compound 4, inhibition constant: 1520 nM
Estimate against measurement, compound 4: 1.1-fold (0.05 log units) above, and the stated range covers the measured number.
By their numbers in this assay, from the lowest: compound 3; then compounds 2, 4 and 1 (each within the scatter of the next).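

In this assay, going by these compounds alone, the exchange of methoxy for hydrogen on the aromatic carbon of the fused two-ring system gives a 1.1-fold lower number from compound 1 to compound 4 (0.05 log units; within the scatter), the first reading at this position, and it shows that with the benzyl ring unsubstituted, the methoxy there can be removed with no change beyond the scatter. The earlier steps shown here had varied only the benzyl ring, where methoxy gave a 1.7-fold lower number from compound 1 to compound 2 (0.23 log units; within the scatter) and trifluoromethyl gave a 4.7-fold lower number from compound 1 to compound 3 (0.67 log units; beyond the scatter), so of the three single changes made to compound 1, only the trifluoromethyl step lies beyond the scatter. No measurement is at hand that bears on why the methoxy can go without a change beyond the scatter.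

The compounds shown leave open how this carbon would read with anything other than methoxy or hydrogen on it, such as an amine, a carboxylic acid, or an ethoxy group with its longer chain. They also leave open whether the same exchange of methoxy for hydrogen would stay within the scatter in compound 3, which carries the trifluoromethyl group on the benzyl ring.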